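Adding a Side Chain to a Potent Thiazole Cytotoxin

This account rests on a few compounds, and the source may have more. Where it says the series, first, only, none or still open, it means among the compounds named here.

Compound 1 `CC(C)(C)c1cnc(CSc2cnc(Nc3ccccn3)s2)o1`: 10 nM
Compound 2 `CC(C)(C)c1cnc(CSc2cnc(Nc3cccnc3)s2)o1`: 50 nM

In a functional assay on A2780 cells (Homo sapiens) for cytotoxicity (a higher number here means a weaker inhibitor, a lower number a stronger inhibitor), compound 1 gives 10 nM, the lowest of the two numbers, while compound 2 gives 50 nM. Among the compounds with values here, the only measured step, a 5.0-fold higher number from compound 1 to compound 2 (0.70 log units; beyond the scatter), concerns where the ring nitrogen sits and does not bear on the change considered here. Compound 3 `CC(C)(CO)CNCc1ccc(Nc2ncc(SCc3ncc(C(C)(C)C)o3)s2)nc1` differs from compound 1 by ((2-(hydroxymethyl)-2-methylpropyl)amino)methyl in place of hydrogen on an aromatic carbon. Nothing measured addresses such an addition, so no step beyond the scatter is expected in either direction. Compound 3 is therefore estimated at 15 nM, within 3 nM to 80 nM, which would mean a 1.5-fold higher number from compound 1 to compound 3 (0.18 log units; within the scatter).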

Compound 3, half-maximal inhibitory concentration: 3 nM
The estimate for compound 3 lay 5.0-fold (0.70 log units) above the measured number; the range from low to high includes it.
By their numbers in this assay, from the lowest: compound 3; then compound 1; then compound 2.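

In this assay, the aromatic carbon two atoms from the ring nitrogen accepts a substituent without any loss of activity. Placing ((2-(hydroxymethyl)-2-methylpropyl)amino)methyl there in place of hydrogen gives a 3.3-fold lower number from compound 1 to compound 3 (0.52 log units; beyond the scatter). The earlier compounds shown here differed only in where the ring nitrogen sits, whereas this result shows that a chain added to this ring can lower the number.

As far as these compounds go, whether a simple aminomethyl group, or a chain ending in a carboxylic acid, would do the same at this carbon remains open. No available data explain the gain.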